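The source may hold more compounds than are shown below. What is called first, only, known or untested is meant among the compounds shown, and "the series" means these compounds.

Of the compounds shown here, two have so far been tested in a functional assay on K562 cells (Homo sapiens) for inhibition, read by sulforhodamine B assay, with a stated time of 48 h; a lower number here means a stronger inhibitor of growth, a higher number a weaker inhibitor of growth. Compound 1 `O=C(Nc1cccc(-n2cc(-c3ccncc3)c(-c3ccc(Cl)c(O)c3)n2)c1)Nc1ccc(Cl)c(Cl)c1` gives > 32500 nM in this assay, and this value is a limit of the assay rather than a measured number. Compound 2 `COc1cc(-c2nn(-c3cccc(NC(=O)c4ccccc4)c3)cc2-c2ccncc2)ccc1Cl` gives > 100000 nM in this assay, which is likewise a limit. Compound 1 thus stands at the limit of > 32500 nM in this assay, at which 1 of the 2 values shown sits, and no real number separates it from compound 2; both values are limits and say nothing about order between the two.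

Compound 3 `O=C(Nc1cccc(-n2cc(-c3ccncc3)c(-c3ccc(Cl)c(O)c3)n2)c1)Nc1ccc(Cl)c(C(F)(F)F)c1` has not yet been measured. It differs from compound 1 in one place: trifluoromethyl in place of chloro on an aromatic carbon. Going by the values given here, no measured pair of compounds shows how a change of this kind affects growth inhibition here, so there is nothing to point to a shift in either direction. The expected step from compound 1 to compound 3 in this assay is a step that the limit leaves unreadable from compound 1 to compound 3, none beyond the scatter. Compound 3 is therefore estimated to give about 50000 nM in this assay, within a range from 15000 nM to 200000 nM, and most likely reported again only as a limit.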

Compound 3, concentration for total growth inhibition: > 32500 nM
Compound 3: only a limit was reported; the forecaster's own chance of this, stated with the estimate: 75%; the middle value lies beyond the limit too.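

Compound 3, like compound 1, is reported in this assay only as a limit and not as a number, so no step from compound 1 to compound 3 can be read: the limit of > 32500 nM in this assay, at which 2 of the 3 values shown sit.

The compounds shown leave open whether trifluoromethyl in place of chloro changes growth inhibition at all, and how strongly any of these compounds inhibits growth.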